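Aryl replacement on the shared core: flat read-out so far

This account rests on a few compounds, and the source may have more. Where it says the series, first, only, none or still open, it means among the compounds named here.

Compound 1 `Cc1nn(-c2nc(-c3ccc(Cl)c(Cl)c3)c(SC(C)C)s2)c(C(=O)O)c1-c1cncnc1` gives 22000 nM in a functional assay on BJAB cells (Homo sapiens) for antiproliferative activity, with a stated time of 4 days; on this read-out lower numbers stand for an effect already at smaller amounts and higher numbers for an effect only at larger amounts of compound. On the numbers available it stands level with compound 3 `Cc1nn(-c2nc(-c3ccc(Cl)c(Cl)c3)c(SC(C)C)s2)c(C(=O)O)c1-c1cccc(C(F)(F)F)c1`, which gives 22000 nM in this assay, and all three measured numbers lie within the scatter of one another: compound 2 `Cc1nn(-c2nc(-c3ccc(Cl)c(Cl)c3)c(SC(C)C)s2)c(C(=O)O)c1-c1cncc(C#N)c1` gives 20000 nM in this assay. The two steps from compound 1, a 1.1-fold lower number from compound 1 to compound 2 (0.04 log units; within the scatter) and no change at the digits printed from compound 1 to compound 3 (within the scatter), and the step of a 1.1-fold higher number from compound 2 to compound 3 (0.04 log units; within the scatter), all show that exchanging the group at this position of the core has so far left the read-out unchanged.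

Compound 4 `COc1cc(C#N)cc(-c2c(C)nn(-c3nc(-c4ccc(Cl)c(Cl)c4)c(SC(C)C)s3)c2C(=O)O)c1` differs from compound 1 by 3-cyano-5-methoxyphenyl in place of pyrimidin-5-yl on an aromatic carbon. The three steps above bear on it directly, as each exchanges the same group at the same place, and none of them moved the number beyond the scatter. No step beyond the scatter is therefore expected in this assay in either direction. Compound 4 is estimated at 22000 nM, with a range of 10000 nM to 48000 nM. The expected step is no change at the digits printed from compound 1 to compound 4 (within the scatter).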

Compound 4, half-maximal effective concentration: 5200 nM
Compound 4: the middle estimate sits 4.2-fold (0.63 log units) above what was measured; measured number below the stated range.
By their numbers in this assay, from the lowest: compound 4; then compounds 2, 1 and 3 (each within the scatter of the next).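

Among these compounds, this position of the shared core is not flat in this assay: 3-cyano-5-methoxyphenyl is the first group here to move the number beyond the scatter, with a 4.2-fold lower number from compound 1 to compound 4 (0.63 log units; beyond the scatter), a 3.8-fold lower number from compound 2 to compound 4 (0.59 log units; beyond the scatter) and a 4.2-fold lower number from compound 3 to compound 4 (0.63 log units; beyond the scatter). Compound 3 also carries a carbon-only ring and compound 2 also carries a nitrile, yet both stay within the scatter of compound 1, so neither feature alone goes with the lower number among these compounds. No measurement available here gives a reason for the step.

On these data alone, it remains open whether a 3-methoxyphenyl group, with the methoxy but no nitrile, would give the same lower number. Also open, as far as these compounds go, is how an amine or a longer alkoxy chain such as ethoxy in place of the methoxy would read in this assay.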